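From 4-bromophenyl to cyclopentyl on a shared core

The compounds below may be only part of what the source reports. "The series", "measured", "known", "first", "only" and "open" are said of these compounds alone.

Among the compounds with values here, in an ADME assay on Vero cells (Chlorocebus sabaeus) for cytotoxicity, read by MTT assay, with a stated time of 72 h (on this read-out higher numbers stand for weaker inhibition and lower numbers for stronger inhibition), compound 1 `O=C(NNC(=O)c1cc([N+](=O)[O-])c[nH]1)Nc1ccc(Br)cc1` gives 378000 nM and compound 2 `O=C(NNC(=O)c1cc([N+](=O)[O-])c[nH]1)Nc1ccc([N+](=O)[O-])cc1` gives 211000 nM, so the only two numbers available lie within the scatter of each other. Compound 3 `O=C(NNC(=O)c1cc([N+](=O)[O-])c[nH]1)NC1CCCC1` carries cyclopentyl in place of 4-bromophenyl on an amide-type nitrogen. Within the data shown here, the one measured step, a 1.8-fold lower number from compound 1 to compound 2 (0.25 log units; within the scatter), put nitro in place of bromo on an aromatic carbon, a smaller change that only loosely bears on this one. No shift beyond the scatter is therefore expected in this assay, and the estimated step is a 1.1-fold lower number from compound 1 to compound 3 (0.03 log units; within the scatter). For compound 3 the estimated value is 350000 nM, with an expected range from 130000 nM to 900000 nM.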

Compound 3, half-maximal inhibitory concentration: 231000 nM
The estimate for compound 3 lay 1.5-fold (0.18 log units) above the measured number; measured number inside the range.
By their numbers in this assay, from the lowest: compounds 2, 3 and 1 (each within the scatter of the next).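

Placing cyclopentyl on the amide-type nitrogen gives a 1.6-fold lower number from compound 1 to compound 3 (0.21 log units; within the scatter) in this assay. The earlier step altered only a substituent on the aromatic ring, whereas here the whole six-membered aromatic ring leaves and a five-membered non-aromatic ring of carbon enters, yet the shift remains within the scatter. No available measurement offers a reason for this result. Still open, on these data alone, is whether an open carbon chain such as hexyl at this place would also fall within the scatter of compound 1, and whether a ring carrying an amine or a carboxylic acid would.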